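Alkyl-for-nitrile swap on the chain of compound 3

The source may report more compounds than this note shows. Statements on the series, on what has been measured and on what is new or still open speak of the compounds shown alone.

Measured so far in an assay on isolated protein for binding affinity to leukotriene B4 receptor 1 (Homo sapiens), tested at 1 uM; a lower number here means less inhibition, a higher number more inhibition at the concentration tested (going by the name of the read-out):
compound 1 `CC(=O)c1ccc(OCCCCC#N)cc1O` — 0%
compound 2 `CCCc1cc(C(C)=O)c(O)cc1OCCCCC#N` — 37%
compound 3 `C=CCc1cc(C(C)=O)c(O)cc1OCCCC#N` — 6%

Compound 3 stands second highest of the three numbers in this assay. Its nearest neighbour is compound 1, whose value sits within the scatter of that of compound 3; the largest gap is to compound 2, which lies well beyond the scatter. Within the data shown here, the only single-point step measured is a number 37 percentage points higher from compound 1 to compound 2 (beyond the scatter), a propyl in place of hydrogen on an aromatic carbon.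

Compound 4 `C=CCc1cc(C(C)=O)c(O)cc1OCCCCCCC` differs from compound 3 in the chain, not on the ring: butyl in place of cyano on a saturated chain carbon, three bonds along the chain from an oxygen on an aromatic ring. Among the measured compounds shown here, no measured step covers an exchange of this kind, so the propyl-for-hydrogen step of compound 1 to compound 2 gives no direct guide, and the expectation rests on little.

Compound 4 is therefore expected to give about 15% in this assay, within 0% to 45%. The step this estimate implies, a number 9 percentage points higher from compound 3 to compound 4 (within the scatter), is not expected to exceed the scatter with confidence.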

Compound 4, a percentage reported as inhibition, at one concentration (the size of the read-out at that concentration, not a potency): 8%
Compound 4: middle estimate off by 7 percentage points, on the high side; measured number inside the range.
By their numbers in this assay, from the lowest: compounds 1, 3 and 4 (each within the scatter of the next); then compound 2.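

On the core of compound 3, butyl in place of cyano on a saturated chain carbon, three bonds along the chain from an oxygen on an aromatic ring, gives a number 2 percentage points higher from compound 3 to compound 4 (within the scatter). Among these compounds, this is the first reading of a change at the chain end, and in this assay the 3-cyanopropyl and heptyl forms of the chain cannot be told apart, so on this core the nitrile shows no mark on the read-out. Nothing at hand bears on why this exchange leaves the number within the scatter.

Open, going by these compounds, is whether an amine or a carboxylic acid at the chain end, or a longer chain, would move the number beyond the scatter. Also open, on these data alone, is whether the same exchange reads alike on the core of compound 2, where the number is higher.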